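A few compounds are considered here, and "the series" means these few. Any claim that something is new, unique, unknown or untested is made for them only; others in the source may bear on it.

Compound 1 `COC(=O)N[C@H](C(=O)N1CCC[C@H]1C(=O)Nc1ccc([C@@H]2CC[C@@H](c3ccc(NC(=O)[C@@H]4CCCN4C(=O)[C@@H](NC(=O)OC)C(C)C)cc3)N2c2ccc([Si](C)(C)C)cc2)cc1)C(C)C` and compound 2 `CC[Si](CC)(CC)c1ccc(N2[C@H](c3ccc(NC(=O)[C@@H]4CCCN4C(=O)[C@@H](NC(=O)OC)C(C)C)cc3)CC[C@H]2c2ccc(NC(=O)[C@@H]3CCCN3C(=O)[C@@H](NC(=O)OC)C(C)C)cc2)cc1` share one core and differ only in a group on an aromatic carbon. In an ADME assay on the whole organism for pharmacokinetics, with Mus musculus as the target, read by HPLC, at a dose of 10 mg/kg by the oral route (on this read-out lower numbers stand for lower exposure and higher numbers for higher exposure at the dose given), compound 1 gives 2910 ng.h/mL, and compound 2 gives 3040 ng.h/mL; the two numbers sit within the scatter of each other, and the change a 1.0-fold higher number from compound 1 to compound 2 (0.02 log units; within the scatter) shows that a larger silicon-bearing group there left exposure unchanged. Compound 3 `COC(=O)N[C@H](C(=O)N1CCC[C@H]1C(=O)Nc1ccc([C@@H]2CC[C@@H](c3ccc(NC(=O)[C@@H]4CCCN4C(=O)[C@@H](NC(=O)OC)C(C)C)cc3)N2c2ccc([Si](C)(C)C(C)(C)C)cc2)cc1)C(C)C` is not yet measured; it carries tert-butyl in place of methyl on a silicon. Among the measured compounds shown here, the only step that bears on it is a 1.0-fold higher number from compound 1 to compound 2 (0.02 log units; within the scatter), so no shift beyond the scatter is expected, giving a 1.0-fold lower number from compound 1 to compound 3 (0.00 log units; within the scatter). Compound 3 is therefore estimated at 2900 ng.h/mL, within 1400 ng.h/mL to 5800 ng.h/mL.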

Compound 3, area under the concentration-time curve: 3520 ng.h/mL
For compound 3 the middle estimate is 1.2-fold (0.08 log units) below the measured one, within the range that was stated.
By their numbers in this assay, from the lowest: compounds 1, 2 and 3 (each within the scatter of the next).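

Putting tert-butyl in place of methyl on a silicon gives a 1.2-fold higher number from compound 1 to compound 3 (0.08 log units; within the scatter) in this assay, and the comparison with the triethyl-bearing silicon group gives a 1.2-fold higher number from compound 2 to compound 3 (0.06 log units; within the scatter). Exposure therefore stays level whether the added carbons sit in one branched tert-butyl group or are spread over the silicon as in compound 2. Nothing available explains why exposure holds steady. All three compounds carry only carbon groups on the silicon, so the shown compounds leave open how an amine or a carboxylic acid there would behave. They also leave open whether a plain carbon in place of the silicon would give similar exposure.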